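Swapping Acetyl for Benzyloxycarbonyl: Permeability Outlook

The source may report more compounds than this note shows. Statements on the series, on what has been measured and on what is new or still open speak of the compounds shown alone.

Compound 1 `Cn1cncc1CN1CC(N(CC2CCN(C(=O)CNC(=O)OC(C)(C)C)CC2)S(=O)(=O)c2ccccn2)Cc2cc(C#N)ccc21`, compound 2 `Cn1cncc1CN1CC(N(CC2CCN(C(=O)c3ccco3)CC2)S(=O)(=O)c2ccccn2)Cc2cc(C#N)ccc21` and compound 3 `CC(=O)N1CCC(CN(C2Cc3cc(C#N)ccc3N(Cc3cncn3C)C2)S(=O)(=O)c2ccccn2)CC1` share one core and differ only in the group on a carbonyl carbon. In an ADME assay on Caco-2 cells (Homo sapiens) for permeability, in the apical to basolateral direction (on this read-out lower numbers stand for lower permeability and higher numbers for higher permeability), compound 1 gives 0.5 10^-6 cm/s, compound 2 gives 0.5 10^-6 cm/s and compound 3 gives 0.5 10^-6 cm/s. The steps of no change at the digits printed from compound 1 to compound 2 (within the scatter), no change at the digits printed from compound 1 to compound 3 (within the scatter) and no change at the digits printed from compound 2 to compound 3 (within the scatter) show that exchanging the group on that carbon has so far left this read-out unmoved, so compound 3 stands level with compounds 1 and 2. Compound 4 `Cn1cncc1CN1CC(N(CC2CCN(C(=O)OCc3ccccc3)CC2)S(=O)(=O)c2ccccn2)Cc2cc(C#N)ccc21` takes the next step: benzyloxy in place of methyl on a carbonyl carbon. All three measured steps bear on this change, as each swaps a group at the same carbonyl carbon, and none moved the value beyond the scatter; the entering group brings an aromatic ring and an extra acceptor, yet the earlier groups already ranged from a small methyl to a bulky carbamate without effect. The expected step of no change at the digits printed from compound 3 to compound 4 (within the scatter) is therefore none beyond the scatter. Compound 4 is estimated at 0.5 10^-6 cm/s, with a range from 0.25 10^-6 cm/s to 1.2 10^-6 cm/s.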

Compound 4, apparent permeability: 1 10^-6 cm/s
Compound 4: middle estimate off by 2.0-fold (0.30 log units), on the low side; the measured number falls inside the stated range.
By their numbers in this assay, from the lowest: compounds 1, 2, 3 and 4 (each within the scatter of the next).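

Benzyloxy is the first group at this carbonyl carbon to bring a six-membered aromatic ring of carbon only, and the read-out in this assay shows a 2.0-fold higher number from compound 3 to compound 4 (0.30 log units; within the scatter) and a 2.0-fold higher number from compound 2 to compound 4 (0.30 log units; within the scatter) and a 2.0-fold higher number from compound 1 to compound 4 (0.30 log units; within the scatter) as well. All three steps stay inside the usual scatter, so four different groups on this carbonyl carbon, from small methyl to eight-heavy-atom benzyloxy, have now given no real separation in this read-out. No measurement shown here explains this flat result.

On these data alone, whether a group of another kind on this carbonyl carbon, such as a carboxylic acid or a basic amine on a longer chain, would separate from these four remains open. The compounds shown also leave open how changes elsewhere on the shared core would behave, since all four keep it the same.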